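This account rests on a few compounds, and the source may have more. Where it says the series, first, only, none or still open, it means among the compounds named here.

In an assay on IMR-32 cells for inhibition of Voltage-dependent N-type calcium channel subunit alpha-1B (Homo sapiens), with a stated time of 5 min (on this read-out higher numbers stand for weaker inhibition and lower numbers for stronger inhibition), compound 1 `COC(OC)C1=C(C(=O)OC/C=C/c2ccccc2)C(c2cccc(Cl)c2)C(C(=O)O)=CN1` gives 1100 nM, compound 2 `COC(OC)C1=C(C(=O)OC/C=C/c2ccccc2)C(c2cc(Cl)cc(Cl)c2)C(C(=O)O)=CN1` gives 1000 nM and compound 3 `COC(OC)C1=C(C(=O)OC/C=C/c2ccccc2)C(c2ccc(Cl)c(Cl)c2)C(C(=O)O)=CN1` gives 520 nM. Compound 3 and compound 2 stand within the scatter of each other, shown by a 1.9-fold lower number from compound 2 to compound 3 (0.28 log units; within the scatter), while compound 1 stands apart, shown by a 2.1-fold lower number from compound 1 to compound 3 (0.33 log units; beyond the scatter). The other step, a 1.1-fold lower number from compound 1 to compound 2 (0.04 log units; within the scatter), also stays within the scatter.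

Compound 4 `COc1ccc(C2C(C(=O)O)=CNC(C(OC)OC)=C2C(=O)OC/C=C/c2ccccc2)cc1Cl` differs from compound 3 in one place: methoxy in place of chloro on an aromatic carbon. Within the data shown here, no measured pair shows what a methoxy group does here; the measured steps only show what a chloro group adds. In compound 1 a single chloro group already gives 1100 nM, and the second chloro group in the position of compound 3 lowers the number modestly, as seen in a 2.1-fold lower number from compound 1 to compound 3 (0.33 log units; beyond the scatter). Taking that chloro group away and putting methoxy in its place could return the number toward that of compound 1, or leave it where compound 3 stands, but nothing shown argues for a large shift in either direction.

Compound 4 is therefore expected to give about 800 nM in this assay, somewhere between 400 nM and 1700 nM, which means an expected 1.5-fold higher number from compound 3 to compound 4 (0.19 log units; within the scatter) that stays within or only just beyond the scatter.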

Compound 4, half-maximal inhibitory concentration: 1500 nM
Compound 4: the middle estimate sits 1.9-fold (0.27 log units) below what was measured; measured number inside the range.
By their numbers in this assay, from the lowest: compounds 3, 2, 1 and 4 (each within the scatter of the next, the first and the last beyond it).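

In this assay, putting methoxy in place of chloro in the 3,4-dichlorophenyl group gives the 3-chloro-4-methoxyphenyl group of compound 4, and this single change produces a 2.9-fold higher number from compound 3 to compound 4 (0.46 log units; beyond the scatter), so this position responds to which group it carries and not only to whether a second chloro group is present on the ring. Methoxy does not hold on to what chloro gained here: with hydrogen at the same place, the comparison gives a 1.4-fold higher number from compound 1 to compound 4 (0.13 log units; within the scatter), and the comparison with the 3,5-dichlorophenyl group gives a 1.5-fold higher number from compound 2 to compound 4 (0.18 log units; within the scatter), so compound 4 cannot be told apart from either compound 1 or compound 2. Nothing available explains why chloro and methoxy differ at this position.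

From the compounds shown here alone, how a hydroxyl group, a longer ethoxy chain or an amine would read at this place remains open, so three groups at one position are too few to support a trend. Also open, going by these compounds, is whether methoxy would give a similar number without the chloro group it sits ortho to in compound 4.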